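Cytotoxicity notes: methoxy to hydrogen on the quinolinone ring

A few compounds are considered here, and "the series" means these few. Any claim that something is new, unique, unknown or untested is made for them only; others in the source may bear on it.

Measured compounds in an ADME assay on L02 cells (Homo sapiens) for cytotoxicity, read by MTT assay, with a stated time of 48 h; on this read-out lower numbers stand for stronger inhibition and higher numbers for weaker inhibition:
Compound 1 `COc1ccc2[nH]c(=O)c(-c3nc4cc(F)ccc4[nH]3)cc2c1` gives > 100000 nM, a limit of the assay.
Compound 2 `COc1ccc2[nH]c(=O)c(-c3nc4cc(C)c(C)cc4[nH]3)cc2c1` gives > 100000 nM, a limit of the assay.
Compound 3 `Cc1ccc2[nH]c(=O)c(-c3nc4cc(F)ccc4[nH]3)cc2c1` gives > 100000 nM, a limit of the assay.

Compound 2 stands only at a limit in this assay, and the other two values shown are limits as well; all three sit at the limit of > 100000 nM in this assay, at which 3 of the 3 values shown sit. Compound 4 `Cc1cc2nc(-c3cc4ccccc4[nH]c3=O)[nH]c2cc1C` is not yet measured. It differs from compound 2 by hydrogen in place of methoxy on an aromatic carbon.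

Going by the values given here, the one measured single-point change, methyl in place of methoxy on an aromatic carbon, is a step that the two limits leave unreadable from compound 1 to compound 3; it concerns the same aromatic carbon but does not remove the group, and its size cannot be read because both ends are limits. Among the compounds with values here, no measured step bears directly on hydrogen in place of methoxy.

The expectation for compound 4 in this assay is therefore a step that the limit leaves unreadable from compound 2 to compound 4, with no change beyond the scatter and a high chance that only a limit is reported again. Compound 4 is estimated at 150000 nM, within 50000 nM to 500000 nM.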

Compound 4, half-maximal inhibitory concentration: > 100000 nM
Compound 4 was reported as a limit; the forecaster's own chance of this, stated with the estimate: 85%; the middle value lies beyond the limit too.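

The step from compound 2 to compound 4, hydrogen in place of methoxy, cannot be read in this assay, as both values are limits. The compounds shown leave open how the four compare and which change, if any, would give a value inside the limit: the limit of > 100000 nM in this assay, at which 4 of the 4 values shown sit.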